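Trimming the Benzyl Ether of a Flavanone to Methoxy

The compounds below may be only part of what the source reports. "The series", "measured", "known", "first", "only" and "open" are said of these compounds alone.

Going by the values given here, compound 2 `O=C1CC(c2ccccc2OCc2ccccc2)Oc2ccccc21` gives 91.5% in a functional assay on J774.A1 cells (Mus musculus) for inhibition, read by immunoassay, with a stated time of 12 h, tested at 30 uM (a lower number here means less inhibition, a higher number more inhibition at the concentration tested (going by the name of the read-out)), the highest of the two numbers known here; compound 1 `CC(C)=CCOc1ccccc1C1CC(=O)c2ccccc2O1` gives 40.3% in this assay. Among the compounds with values here, the only step that bears on the new change is a number 51.2 percentage points higher from compound 1 to compound 2 (beyond the scatter), which shows that the group on this saturated chain carbon matters greatly. Compound 3 `COc1ccccc1C1CC(=O)c2ccccc2O1` differs from compound 2 by hydrogen in place of phenyl on a saturated chain carbon bound to an oxygen on an aromatic ring. Since removing the phenyl goes the opposite way from the change that raised inhibition, a substantial drop is expected, a number 41.5 percentage points lower from compound 2 to compound 3 (beyond the scatter). Compound 3 is therefore estimated at 50%, within 20% to 80%.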

Compound 3, a percentage reported as inhibition, at one concentration (the size of the read-out at that concentration, not a potency): 38.3%
Beside the measured number, compound 3's estimate is 11.7 percentage points above it, and the stated range covers the measured number.
By their numbers in this assay, from the lowest: compounds 3 and 1 (each within the scatter of the next); then compound 2.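

In this assay there is a number 53.2 percentage points lower from compound 2 to compound 3 (beyond the scatter) but a number 2 percentage points lower from compound 1 to compound 3 (within the scatter) at the same place, so the high number of compound 2 does not come with just any group on this carbon. Among the three groups shown, only phenyl separates from hydrogen, while 2-methylprop-1-en-1-yl does not. Going by these compounds, whether a substituted phenyl, a cyclohexyl group or a longer chain ending in phenyl would hold the number at this place remains open. Nothing measured here gives a reason for the gap.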